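Methyl in place of (propylcarbonyl)oxy on the shared core

A few compounds are considered here, and "the series" means these few. Any claim that something is new, unique, unknown or untested is made for them only; others in the source may bear on it.

In a functional assay on A549 cells (Homo sapiens) for cytotoxicity, with a stated time of 48 h (a lower number here means a stronger inhibitor, a higher number a weaker inhibitor), three compounds have been measured: compound 1 (`CC(=O)Oc1ccc2oc(/C=C/[S+](C)[O-])cc(=O)c2c1`) gives 4100 nM and compound 2 (`CCCCCOc1ccc2oc(/C=C/[S+](C)[O-])cc(=O)c2c1`) gives 1600 nM while compound 3 (`CCCC(=O)Oc1ccc2oc(/C=C/[S+](C)[O-])cc(=O)c2c1`) gives 2200 nM as its reading. Compound 3 lies within the scatter of both others: a 1.9-fold lower number from compound 1 to compound 3 (0.27 log units; within the scatter) and a 1.4-fold higher number from compound 2 to compound 3 (0.14 log units; within the scatter) are the steps that link it to them. Only a 2.6-fold lower number from compound 1 to compound 2 (0.41 log units; beyond the scatter) goes beyond the scatter, and that step is modest.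

Compound 4 (`Cc1ccc2oc(/C=C/[S+](C)[O-])cc(=O)c2c1`) has not been measured. Among the measured compounds shown here, it carries methyl in place of (propylcarbonyl)oxy on an aromatic carbon as its single change from compound 3. For the measured compounds named here, all three measured compounds keep an oxygen on that aromatic carbon, so no measured step removes it and the steps above bear on the change only indirectly. They do show a narrow span of numbers. Compound 1, which carries acetyl, gives 4100 nM and offers a weak hint toward a higher number, though no more than a hint. The estimated change is a 1.4-fold higher number from compound 3 to compound 4 (0.13 log units; within the scatter) in this assay and so no step beyond the scatter is expected. For compound 4 the estimate is 3000 nM with an expected range from 1200 nM to 8000 nM around that value.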

Compound 4, half-maximal inhibitory concentration: 1700 nM
Compound 4: middle estimate off by 1.8-fold (0.25 log units), on the high side; low and high end bracket the measured number.
By their numbers in this assay, from the lowest: compounds 2, 4, 3 and 1 (each within the scatter of the next, the first and the last beyond it).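

In this assay, taking the oxygen off this aromatic carbon altogether leaves the reading in place: methyl, which has no hydrogen-bond acceptors, gives a 1.3-fold lower number from compound 3 to compound 4 (0.11 log units; within the scatter) and, against the ether, a 1.1-fold higher number from compound 2 to compound 4 (0.03 log units; within the scatter). At this position, then, methyl, (propylcarbonyl)oxy and pentyloxy cannot be told apart, which the earlier compounds could not show because all of them kept that oxygen; the chain on it and the oxygen itself both appear dispensable for this reading among these compounds. Acetoxy alone separates from methyl, with a 2.4-fold lower number from compound 1 to compound 4 (0.38 log units; beyond the scatter), a modest step that runs the same way as the one from acetoxy to pentyloxy, though compound 1 and compound 3 remain within the scatter of each other, and nothing in the data accounts for why these groups read as they do.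

From the compounds shown here alone, whether a free hydroxyl, an amine or a carboxylic acid on this aromatic carbon would stay in the same narrow span remains open. So does whether a plain hydrogen there, or a longer chain joined directly through carbon, would hold the reading or finally move it beyond the scatter.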